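The source may hold more compounds than are shown below. What is called first, only, known or untested is meant among the compounds shown, and "the series" means these compounds.

Compound 1 `CON(C)C(=O)[C@@H]1CC=C(CCC=C(C)C)C[C@H]1c1ccccc1` and compound 2 `CC(C)=CCCC1=CC[C@@H](C(N)=O)[C@H](c2ccccc2)C1` are the measured pair.

In an assay on isolated protein for inhibition of Apoptosis regulator Bcl-2 (Homo sapiens), read by fluorescence polarization, with stated times of 5 min and 10 min (a lower number here means a stronger inhibitor, a higher number a weaker inhibitor), compound 1 gives only a limit, > 23000 nM. In this assay compound 2 likewise gives only a limit, > 23000 nM. Both values sit at the limit of > 23000 nM in this assay, at which 2 of the 2 values shown sit, so the step that the two limits leave unreadable from compound 1 to compound 2 cannot be read, and compound 2 stands at the limit rather than at a number. Compound 3 `CC(C)=CCCC1=CC[C@@H](C(=O)Nc2ccc(O)cc2)[C@H](c2ccccc2)C1` carries the change (4-hydroxyphenyl in place of hydrogen on an amide-type nitrogen). No measured step bears on it; the only step shown is unreadable, so no direction beyond the scatter is expected for an at least 1.1-fold lower number from compound 2 to compound 3 (0.06 log units; that floor lies within the scatter). Compound 3 is therefore expected near 20000 nM, between 5000 nM and 60000 nM in this assay.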

Compound 3, inhibition constant: > 23000 nM
Compound 3: a limit, no number (the forecaster's own chance of this, stated with the estimate: 60%); at least 1.1-fold (0.06 log units) between middle value and limit.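

Among these compounds, compound 3 also gives only a limit, so no step among compound 1, compound 2 and compound 3 can be read: the limit of > 23000 nM in this assay, at which 3 of the 3 values shown sit. These compounds leave open whether any change on the amide-type nitrogen would give a readable number in this assay.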